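A few compounds are considered here, and "the series" means these few. Any claim that something is new, unique, unknown or untested is made for them only; others in the source may bear on it.

Compound 3 `COc1cc(N)c(Cl)cc1NC(=O)C1CCN(Cc2ccc([N+](=O)[O-])cc2)CC1` was tested in a functional assay on the whole organism for antagonist activity, with Mus musculus as the target; a higher number here means that more compound is needed for the effect, a lower number that less compound is needed. In this assay compound 3 gives > 4 mg/kg, which is a limit of the assay and not a number. Compound 1 `COc1cc(N)c(Cl)cc1NC(=O)C1CCN(Cc2cccc(C#N)c2)CC1` gives > 4 mg/kg in this assay, again a limit. Compound 2 `COc1cc(N)c(Cl)cc1NC(=O)C1CCN(CC2CCCCCC2)CC1` gives > 10 mg/kg in this assay, also a limit. Compound 4 `COc1cc(N)c(Cl)cc1NC(=O)C1CCN(Cc2ccc(C)c(C)c2)CC1` differs from compound 3 in one place: 3,4-dimethylphenyl in place of 4-nitrophenyl on a saturated chain carbon bound to an amine nitrogen in a ring. The steps that alter the same group, a step that the two limits leave unreadable from compound 1 to compound 3 and a step that the two limits leave unreadable from compound 2 to compound 3, have no readable size because the limit of > 4 mg/kg in this assay, at which 2 of the 3 values shown sit, and the limit of > 10 mg/kg in this assay, at which 1 of the 3 values shown sits, mark every value shown. None of these steps therefore sets a size or direction for the change from compound 3 to compound 4. The step that the limit leaves unreadable from compound 3 to compound 4 is therefore what is expected, an estimate only. Compound 4 is expected to give about 6 mg/kg in this assay, between 2 mg/kg and 20 mg/kg, quite possibly once more as a limit.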

Compound 4, dose for half-maximal effect: > 8 mg/kg
Compound 4: a limit, no number; the forecaster's own chance of this, stated with the estimate: 65%; middle value at least 1.3-fold (0.12 log units) away from the limit.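

In this assay compound 4 gives > 8 mg/kg, which is a limit and not a number, so its steps from compound 1, compound 2 and compound 3 cannot be read. On these data alone, with only limits for all four compounds, how much of each is needed for the effect stays open.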